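A few compounds are considered here, and "the series" means these few. Any claim that something is new, unique, unknown or untested is made for them only; others in the source may bear on it.

The measured compounds in a functional assay on A549 cells (Homo sapiens) for inhibition, read by MTT assay and WST assay, with a stated time of 72 h, tested at 10 uM; a higher number here means more inhibition of growth at the concentration tested, a lower number less inhibition of growth:

Compound 1 `O=C(Nc1ccc(Cl)cc1)Nc1ccc(Oc2ccc(-c3nccs3)cc2)cc1` gives 17.7%.
Compound 2 `O=C(Nc1ccccc1)Nc1ccc(Oc2ccc(-c3nccs3)cc2)cc1` gives "not determined" (no result reported).
Compound 3 `O=C(Nc1ccc(Cl)cc1)Nc1ccc(Oc2ccc(-c3ncc[nH]3)cc2)cc1` gives 8.86%.

Among the measured compounds shown here, compound 3 stands lowest of the two numbers in this assay, its nearest neighbour being compound 1, and the one step that joins them, a number 8.8 percentage points lower from compound 1 to compound 3 (within the scatter), lies within the scatter. Compound 2 carries no number, so it adds nothing to the picture.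

Compound 4 `O=C(Nc1ccccc1)Nc1ccc(Oc2ccc(-c3ncc[nH]3)cc2)cc1` follows from compound 3 by the change (hydrogen in place of chloro on an aromatic carbon), that is, hydrogen in place of chloro on an aromatic carbon, para to a large group. For the measured compounds named here, no measured step bears on this change: the only step on record is the one from compound 1 to compound 3, which exchanges the five-membered ring, and the pair of compound 1 and compound 2, which would show the same loss of chloro, has no number for compound 2. Nothing in the data therefore points to a step beyond the scatter in this assay, in either direction.

On that basis compound 4 is estimated at 8%, in the range 0% to 22%, which would mean an expected step of a number 0.9 percentage points lower from compound 3 to compound 4 (within the scatter).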

Compound 4, percent growth inhibition at one concentration: 7.09%
Compound 4: the middle estimate sits 0.9 percentage points above what was measured; low and high end bracket the measured number.
By their numbers in this assay, from the lowest: compounds 4, 3 and 1 (each within the scatter of the next, the first and the last beyond it).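

Among the compounds shown here, compound 3 and compound 4 give the first readable pair for hydrogen in place of chloro on an aromatic carbon, para to a large group: in this assay the change appears as a number 1.8 percentage points lower from compound 3 to compound 4 (within the scatter) with the 1H-imidazol-2-yl group held constant. With that group present, the 4-chlorophenyl and phenyl compounds cannot be told apart in this assay at the single concentration tested, so the data show no measurable role for the chloro at this position. No accompanying measurement offers any explanation of this result.

Going by these compounds, compound 2 carries no number, so the same change cannot be read with the 1,3-thiazol-2-yl group in place, and it remains open whether the result for the chloro holds beyond the 1H-imidazol-2-yl pair. Also open, on these data alone, is how a fluoro, a methoxy, an amine or a carboxylic acid at this same place on the phenyl ring would read in this assay, and whether any of these would move the number beyond the scatter.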